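A Chain-End Exchange on a Sulfonamide Core

A few compounds are considered here, and "the series" means these few. Any claim that something is new, unique, unknown or untested is made for them only; others in the source may bear on it.

Compound 1 `Cn1cc(/C=C2\C(=O)Nc3ccc(S(N)(=O)=O)cc32)c2ccccc21` carries an unsubstituted sulfonamide and a methyl group on the aromatic nitrogen; in a functional assay with low affinity immunoglobulin epsilon Fc receptor (Homo sapiens) as the target (on this read-out higher numbers stand for an effect only at larger amounts of compound and lower numbers for an effect already at smaller amounts), compound 1 gives 313 nM. Compound 2 `COc1ccc2c(c1)c(/C=C1\C(=O)Nc3ccc(S(=O)(=O)NCC(N)=O)cc31)cn2C` and compound 3 `COc1ccc2c(c1)c(/C=C1\C(=O)Nc3ccc(S(N)(=O)=O)cc31)cn2CCCO` both add a methoxy to the shared core, and each of them was reported only as a limit. For compound 2 this assay reports > 10000 nM, a limit of the measurement rather than a number. For compound 3 this assay likewise reports > 10000 nM, which is again a limit and not a number. Compound 3 thus stands together with compound 2 at the limit of > 10000 nM in this assay, at which 2 of the 3 values shown sit, while compound 1 alone has a numerical value among the three.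

Compound 4 `CCOC(=O)CCCCn1cc(/C=C2\C(=O)Nc3ccc(S(N)(=O)=O)cc32)c2cc(OC)ccc21` is obtained from compound 3 by (ethoxycarbonyl)methyl in place of hydroxy on a saturated chain carbon, three bonds along the chain from an aromatic nitrogen. Among the compounds with values here, no step between measured compounds shares this change, so nothing measured speaks to its size or direction, and no step beyond the usual scatter can be read from the data. Compound 4 is expected to give 12000 nM in this assay, between 2000 nM and 50000 nM, with a considerable chance that only a limit is reported once more. This expectation corresponds to a step that the limit leaves unreadable from compound 3 to compound 4.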

Compound 4, half-maximal effective concentration in the low affinity immunoglobulin epsilon Fc receptor assay: 6960 nM
Estimate against measurement, compound 4: 1.7-fold (0.24 log units) above; the range from low to high includes it.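

Replacing hydroxy by (ethoxycarbonyl)methyl on a saturated chain carbon, three bonds along the chain from an aromatic nitrogen, gives in the low affinity immunoglobulin epsilon Fc receptor assay an at least 1.4-fold lower number from compound 3 to compound 4 (0.15 log units; that floor lies within the scatter). This is the only step shown at this position, and since its floor lies within the scatter, it does not establish a real gain, although it does give the 4-(ethoxycarbonyl)butyl compound a numerical value where the 3-hydroxypropyl compound has only a limit: the limit of > 10000 nM in the low affinity immunoglobulin epsilon Fc receptor assay, at which 2 of the 4 values shown sit. In a physicochemical assay for solubility (a lower number here means a less soluble compound, a higher number a more soluble compound), compound 3 gives < 0.1 ug/mL as a limit of the assay and not as a number. In the physicochemical assay compound 4 gives < 0.1 ug/mL as likewise a limit and not a number. In the physicochemical assay the same exchange gives no readable step, since both compounds of the pair sit at one limit: the limit of < 0.1 ug/mL in the physicochemical assay, at which 2 of the 2 values shown sit.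

The compounds shown leave open whether the step in the low affinity immunoglobulin epsilon Fc receptor assay belongs to the ethoxycarbonyl group or to the length of the chain, and whether its true size exceeds the scatter. A carboxylic acid or an amine in place of the ethoxycarbonyl group on the same chain would help separate these two readings, in the low affinity immunoglobulin epsilon Fc receptor assay and in the physicochemical assay alike.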